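Hydroxy to Ethoxy on a Shared Urea Core

The compounds below may be only part of what the source reports. "The series", "measured", "known", "first", "only" and "open" are said of these compounds alone.

Compound 1 `Cc1cc(C(=O)N2CCCCc3ccccc32)ccc1CNC(=O)Nc1c(F)cccc1F` and compound 2 `Cc1cc(C(=O)N2CCCCc3ccccc32)ccc1CNC(=O)N1C[C@H](O)C[C@H]1C(=O)N(C)C` share one core and differ only at a carbonyl substituent. In a functional assay on HEK293 cells for agonist activity at Vasopressin V2 receptor (Homo sapiens), read by a luciferase reporter and cAMP accumulation (a higher number here means that more compound is needed for the effect, a lower number that less compound is needed), compound 1 gives 2.1 nM. Compound 2 gives 2.3 nM, and the step of a 1.1-fold higher number from compound 1 to compound 2 (0.04 log units; within the scatter) stays within the scatter. Compound 3 `CCO[C@@H]1C[C@@H](C(=O)N(C)C)N(C(=O)NCc2ccc(C(=O)N3CCCCc4ccccc43)cc2C)C1` differs from compound 2 by ethyl in place of hydrogen on an oxygen on a saturated carbon. Among the measured compounds shown here, no measured step touches this oxygen; the single step available changes a different part of the molecule, so it offers no direct guide. Compound 3 is expected to show a 1.3-fold higher number from compound 2 to compound 3 (0.12 log units; within the scatter), a small movement. Compound 3 is therefore estimated at 3 nM, within 1 nM to 10 nM.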

Compound 3, half-maximal effective concentration: 4.3 nM
Compound 3: middle estimate off by 1.4-fold (0.16 log units), on the low side, within the range that was stated.
By their numbers in this assay, from the lowest: compounds 1, 2 and 3 (each within the scatter of the next, the first and the last beyond it).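

Among the compounds shown here, the first measured step at this oxygen, ethyl in place of hydrogen, is a 1.9-fold higher number from compound 2 to compound 3 (0.27 log units; within the scatter), so going from hydroxy to ethoxy gives no difference that can be told from the scatter. The free hydroxy hydrogen is therefore not needed here for a low number in this assay. Nothing available gives a reason for this result.

Still open, on these data alone, is whether a longer chain, such as butoxy, would also stay within the scatter of compound 2. The same question applies to an amine at this carbon in place of the oxygen.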